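From chloro to trifluoromethyl on a shared core

The source may report more compounds than this note shows. Statements on the series, on what has been measured and on what is new or still open speak of the compounds shown alone.

Measured so far in a functional assay on MOLT-4 cells (Homo sapiens) for antiproliferative activity, read by MTT assay, with a stated time of 48 h; a higher number here means a weaker inhibitor, a lower number a stronger inhibitor:
Compound 1 `COc1ccc(Nc2nc(Nc3cnn(CCCCCCC(=O)NO)c3)ncc2Cl)cc1`: 170 nM
Compound 2 `O=C(CCCCCCn1cc(Nc2ncc(Cl)c(Nc3ccc(F)cc3)n2)cn1)NO`: 220 nM

Within the data shown here, only two values are available in this assay. Compound 2, at 220 nM, lies within the scatter of compound 1, at 170 nM, so the two cannot be told apart. The next analogue is compound 3 `O=C(CCCCCCn1cc(Nc2ncc(C(F)(F)F)c(Nc3ccc(F)cc3)n2)cn1)NO`, which differs from compound 2 in a single group. The change is trifluoromethyl in place of chloro on an aromatic carbon, ortho to a (4-fluorophenyl)amino group. Among the measured compounds shown here, no measured pair covers this exchange, so the data give no direct reading of it. For the measured compounds named here, the only guide is the step of a 1.3-fold higher number from compound 1 to compound 2 (0.11 log units; within the scatter), which involves fluoro in place of methoxy, a different group, and therefore bears on the new change only indirectly. On that slender evidence, no step beyond the scatter is expected in this assay, and neither direction is favoured. The expected step is a 1.1-fold higher number from compound 2 to compound 3 (0.06 log units; within the scatter). The estimated value for compound 3 is 250 nM, with an expected range from 100 nM to 600 nM.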

Compound 3, half-maximal inhibitory concentration: 240 nM
The estimate for compound 3 lay 1.0-fold (0.02 log units) above the measured number; the range from low to high includes it.
By their numbers in this assay, from the lowest: compounds 1, 2 and 3 (each within the scatter of the next).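

In this assay, trifluoromethyl in place of chloro on an aromatic carbon, ortho to a (4-fluorophenyl)amino group, gives a 1.1-fold higher number from compound 2 to compound 3 (0.04 log units; within the scatter), so at this position a group of 4 heavy atoms can stand where one of a single heavy atom stood without the read-out leaving the scatter. The earlier step, a 1.3-fold higher number from compound 1 to compound 2 (0.11 log units; within the scatter), concerned fluoro in place of methoxy at a different place on the shared core and gave no reading of this position. No supporting measurement is available to explain this result.

The compounds shown carry only chloro or trifluoromethyl at this position, and only compound 2 and compound 3 compare them, both with the (4-fluorophenyl)amino group, so it remains open whether a methyl group, a nitrile or an amine here would give a step beyond the scatter, and whether the exchange would read the same alongside the methoxy group of compound 1. All three compounds also share one chain ending in a hydroxamic acid, which leaves open what a shorter chain or a carboxylic acid at that end would do in this assay.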